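The source may hold more compounds than are shown below. What is called first, only, known or untested is meant among the compounds shown, and "the series" means these compounds.

Measured compounds:
- compound 1, `Cc1nc(N2CCN(C3CCOCC3)CC2)nc2ccc(NC(=O)COc3ccc(Cl)cc3)cc12`: 45 nM
- compound 2, `Cc1nc(N2CCN(C(=O)C3CC3)CC2)nc2ccc(NC(=O)COc3ccc(OC(F)(F)F)cc3)cc12`: 49 nM

In an assay on CHO-K1 cells for displacement of a labelled ligand from melanin-concentrating hormone receptor 1 (Homo sapiens), with a stated time of 2 h (on this read-out lower numbers stand for stronger inhibition and higher numbers for weaker inhibition), compound 1 gives 45 nM and compound 2 gives 49 nM; the two numbers lie within the usual scatter of each other, so neither compound can be placed ahead of the other. Compound 3, `Cc1nc(N2CCN(C3CCOCC3)CC2)nc2ccc(NC(=O)COc3ccc(OC(F)(F)F)cc3)cc12`, has not yet been measured. It differs from compound 2 in one place: oxan-4-yl in place of cyclopropylcarbonyl on an amine nitrogen in a ring. The group that enters is the one already present on the amine nitrogen in the ring of compound 1, while the aryl ether of compound 2 is kept, so compound 3 joins features seen in both measured compounds. Among the compounds with values here, no measured step covers this exchange. Given that compound 1 gives 45 nM with the same ring group, the step of a 1.1-fold lower number from compound 2 to compound 3 (0.04 log units; within the scatter) is expected to be small, with no direction beyond the scatter. Compound 3 is therefore estimated at 45 nM, with a range of 20 nM to 100 nM.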

Compound 3, half-maximal inhibitory concentration: 7 nM
The estimate for compound 3 lay 6.4-fold (0.81 log units) above the measured number, and the stated range ends above it.
By their numbers in this assay, from the lowest: compound 3; then compounds 1 and 2 (each within the scatter of the next).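

In this assay the group on the amine nitrogen in the ring clearly matters: with the trifluoromethoxy aryl ether kept, oxan-4-yl in place of cyclopropylcarbonyl gives a 7.0-fold lower number from compound 2 to compound 3 (0.85 log units; beyond the scatter) on this exchange alone. The substituent on the aromatic carbon matters as well, as trifluoromethoxy in place of chloro gives a 6.4-fold lower number from compound 1 to compound 3 (0.81 log units; beyond the scatter) with oxan-4-yl kept, so the closeness of the two earlier numbers did not mean that either exchange was without effect. Nothing available here accounts for either step.

As far as these compounds go, whether the step for oxan-4-yl keeps its size with chloro on the aromatic carbon remains open. Also open, from the compounds shown here alone, is how an acetyl group or a simple methyl on that ring nitrogen, or a trifluoromethyl group on the aromatic carbon, would read.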